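The source may hold more compounds than are shown below. What is called first, only, known or untested is meant among the compounds shown, and "the series" means these compounds.

Of the compounds shown here, three have so far been measured in a functional assay on the whole organism (strain Wistar Albino) for inhibition, with Rattus norvegicus as the target, read by paw edema, with a stated time of 3 h, at a dose of 20 mg/kg; a higher number here means more inhibition at the dose given (going by the name of the read-out), a lower number less inhibition. Compound 1 `COc1ccc(Cl)c(-c2nnc3n2NC(c2ccc[nH]2)S3)c1` gives 18.4% in this assay, compound 3 `COc1ccc(Cl)c(-c2nnc3n2NC(c2cccn2C)S3)c1` gives 18.5%, and compound 2 `Cc1occc1-c1nnc2n1NC(c1ccc[nH]1)S2` gives 20.3%. The difference between the core of compound 1 and the core of compound 2 is not broken down here. All three values lie within the scatter of one another, so no order among them can be read from these numbers. Compound 1 and compound 3 differ in one place: methyl in place of hydrogen on an aromatic nitrogen. That change gives a number 0.1 percentage points higher from compound 1 to compound 3 (within the scatter).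

Compound 4 `Cc1occc1-c1nnc2n1NC(c1cccn1C)S2` has not yet been measured in this assay. It differs from compound 2 in the same way: methyl in place of hydrogen on an aromatic nitrogen. The place of the change is described in the same words for both pairs, so the change made on the core of compound 2 is the same one already seen on the core of compound 1. Because a number 0.1 percentage points higher from compound 1 to compound 3 (within the scatter) lay within the scatter, a step of similar size is expected here, a number 0.2 percentage points higher from compound 2 to compound 4 (within the scatter). Compound 4 is therefore expected to give about 20.5% in this assay, with a likely span from 12% to 29%.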

Compound 4, a percentage reported as inhibition, in the whole organism at one dose (the size of the read-out at that dose, not a potency): 21.5%
Estimate against measurement, compound 4: 1 percentage points below; the measured number falls inside the stated range.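

In this assay, methyl in place of hydrogen on the aromatic nitrogen gives a number 1.2 percentage points higher from compound 2 to compound 4 (within the scatter), and set beside the earlier step the comparison reads: the same change on two cores in this assay, a number 0.1 percentage points higher (within the scatter) from compound 1 to compound 3 and a number 1.2 percentage points higher (within the scatter) from compound 2 to compound 4, 1.1 percentage points apart, within the scatter of two such steps. The change therefore carries from the core of compound 1 to the core of compound 2 with no difference between the two steps that can be told apart, and neither step can be separated from the scatter. This does not show that the methyl raises or lowers inhibition on either core, nor that the steps are truly equal, and two cores say nothing about how the change would read on a further core.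

The compounds shown leave open whether any group on that aromatic nitrogen gives a step beyond the scatter, for instance a longer chain such as propyl, or a chain ending in an amine or a carboxylic acid. Also open, from the compounds shown here alone, is how 1H-pyrrol-2-yl and 1-methyl-1H-pyrrol-2-yl compare on any other core.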